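This account rests on a few compounds, and the source may have more. Where it says the series, first, only, none or still open, it means among the compounds named here.

Measured in a functional assay on LoVo cells (Homo sapiens) for inhibition, read by MTT assay, with a stated time of 72 h; on this read-out lower numbers stand for stronger inhibition and higher numbers for weaker inhibition:

- compound 1 `COc1cccc(/C=C/C(=O)Nc2cc(OC)c(OC)c(OC)c2)c1`: 43000 nM
- compound 2 `C=C(Br)C(=O)Nc1cccc(/C=C/C(=O)Nc2cccc3ccccc23)c1`: 1160 nM
- compound 3 `C=C(Br)C(=O)Nc1cccc(/C=C/C(=O)Nc2ccc(F)cc2)c1`: 4800 nM

Compound 3 sits in the middle of these three numbers, above compound 2 and below compound 1, and both gaps are beyond the usual scatter. Compound 4 `C=C(Br)C(=O)Nc1cccc(/C=C/C(=O)Nc2ccc(C)cc2)c1` changes a single place in compound 3: methyl in place of fluoro on an aromatic carbon. For the measured compounds named here, no measured pair here differs in only one place, so the data offer no direct guide to this swap. The best anchor is compound 3 itself at 4800 nM. The estimated 1.1-fold lower number from compound 3 to compound 4 (0.03 log units; within the scatter) is small, expected to stay within the scatter, with no firm direction. For compound 4 the estimated value is 4500 nM, with an expected range from 2000 nM to 10000 nM.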

Compound 4, half-maximal inhibitory concentration: 1500 nM
Estimate against measurement, compound 4: 3.0-fold (0.48 log units) above; the measured number lies below the stated range.
By their numbers in this assay, from the lowest: compounds 2 and 4 (each within the scatter of the next); then compound 3; then compound 1.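

In this assay, for the compounds shown here, methyl in place of fluoro on an aromatic carbon para to a large group gives a 3.2-fold lower number from compound 3 to compound 4 (0.51 log units; beyond the scatter) and is the first direct reading at this position. It shows that the number responds here to exchanging one heavy atom for another, so this place on the ring is not indifferent to what it carries. No measurement here explains why the number falls with this swap.

As far as these compounds go, whether an amine, a carboxylic acid or a longer chain at this position would lower the number further or raise it remains open. So does whether methyl would have a similar effect on the other aromatic carbons of this ring.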